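The compounds below may be only part of what the source reports. "The series", "measured", "known", "first", "only" and "open" are said of these compounds alone.

Measured compounds in a functional assay on HepG2 cells (Homo sapiens) for antiproliferative activity, read by MTT assay, with a stated time of 48 h; on this read-out higher numbers stand for weaker inhibition and lower numbers for stronger inhibition:
compound 1 `COc1ccc(-c2ccc3c(c2)C(=O)C(=O)N3)cc1` gives 960 nM
compound 2 `COc1ccc(-c2ccc3c(c2)C(=O)C(=O)N3C)cc1` gives 6670 nM
compound 3 `CCN1C(=O)C(=O)c2cc(-c3ccc(OC)cc3)ccc21` gives 4470 nM

Compound 1 has the lowest number of the three, which in this assay means the strongest inhibition; compound 3 stands nearest to it and compound 2 furthest, and both gaps are beyond the usual scatter. Compound 4 `COc1ccc(CN2C(=O)C(=O)c3cc(-c4ccc(OC)cc4)ccc32)cc1` has not been measured yet. It differs from compound 1 in a single place: 4-methoxybenzyl in place of hydrogen on an amide-type nitrogen in a ring. For the measured compounds named here, two measured steps bear on this. They replace the same hydrogen with methyl or ethyl: a 6.9-fold higher number from compound 1 to compound 2 (0.84 log units; beyond the scatter) and a 4.7-fold higher number from compound 1 to compound 3 (0.67 log units; beyond the scatter). In both cases the number went modestly up, that is, inhibition became weaker. The remaining step, a 1.5-fold lower number from compound 2 to compound 3 (0.17 log units; within the scatter), lies within the scatter. Nothing measured shows how a 4-methoxybenzyl group behaves at this nitrogen, so the expectation rests on those two steps and is a modest rise, a 6.3-fold higher number from compound 1 to compound 4 (0.80 log units; beyond the scatter). Compound 4 is therefore estimated at 6000 nM, with a likely range from 1500 nM to 25000 nM.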

Compound 4, half-maximal inhibitory concentration: 50 nM
Estimate against measurement, compound 4: 120-fold (2.08 log units) above; the whole stated range lies above it.
By their numbers in this assay, from the lowest: compound 4; then compound 1; then compounds 3 and 2 (each within the scatter of the next).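

At this amide-type nitrogen in a ring, the effect of a substituent depends strongly on which group it is: methyl and ethyl weakened inhibition, but in this assay 4-methoxybenzyl gives a 19-fold lower number from compound 1 to compound 4 (1.28 log units; beyond the scatter), so replacing the hydrogen here can also strengthen inhibition. The saturated chain carbon bound to that nitrogen also matters far more than the small chains suggested, with 4-methoxyphenyl on that carbon giving an 89-fold lower number from compound 3 to compound 4 (1.95 log units; beyond the scatter) in place of methyl and a 130-fold lower number from compound 2 to compound 4 (2.13 log units; beyond the scatter) in place of hydrogen. Nothing available explains why this group has such an effect.

The compounds shown do not separate the contribution of the aromatic ring from that of its methoxy group, as plain benzyl is not among them. They also leave open how a longer chain ending in the same ring, or a benzyl group carrying an amine or a carboxylic acid, would behave at this nitrogen.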